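A few compounds are considered here, and "the series" means these few. Any claim that something is new, unique, unknown or untested is made for them only; others in the source may bear on it.

In a functional assay on PANC-1 cells (Homo sapiens) for cytotoxicity, read by MTT assay, with a stated time of 72 h (a higher number here means a weaker inhibitor, a lower number a stronger inhibitor), compound 1 (`O=C1C(Nc2ccc(C3CCCCC3)cc2)=CC(=O)c2ncncc21`) gives 900 nM, compound 2 (`CCc1ccc(-c2ccc(NC3=CC(=O)c4ncncc4C3=O)cc2)cc1`) gives 2300 nM and compound 3 (`O=C1C(Nc2ccc(N3CCCCC3)cc2)=CC(=O)c2ncncc21`) gives 1400 nM. Compound 3 sits within the scatter of both other compounds. Among the compounds with values here, the only step beyond the scatter is a 2.6-fold higher number from compound 1 to compound 2 (0.41 log units; beyond the scatter).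

Compound 4 (`O=C1C(Nc2ccc(-c3ccccn3)cc2)=CC(=O)c2ncncc21`) carries pyridin-2-yl in place of piperidin-1-yl on an aromatic carbon. Within the data shown here, the closest precedent is a 1.6-fold lower number from compound 2 to compound 3 (0.22 log units; within the scatter), which also exchanges piperidin-1-yl and a six-membered aromatic ring, though in the reverse sense and with a different ring. Also relevant is a 1.6-fold higher number from compound 1 to compound 3 (0.19 log units; within the scatter). Both are small, so no step beyond the scatter is expected in this assay. The estimated step is a 1.3-fold higher number from compound 3 to compound 4 (0.11 log units; within the scatter). The expected value for compound 4 is 1800 nM, with an estimated range of 700 nM to 4500 nM.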

Compound 4, half-maximal inhibitory concentration: 800 nM
Estimate against measurement, compound 4: 2.3-fold (0.35 log units) above; low and high end bracket the measured number.
By their numbers in this assay, from the lowest: compounds 4, 1, 3 and 2 (each within the scatter of the next, the first and the last beyond it).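

At this position, para to a large group, pyridin-2-yl does not separate from the non-aromatic rings: replacing piperidin-1-yl gives a 1.8-fold lower number from compound 3 to compound 4 (0.24 log units; within the scatter) and replacing cyclohexyl gives a 1.1-fold lower number from compound 1 to compound 4 (0.05 log units; within the scatter), both within the scatter. Replacing 4-ethylphenyl gives a 2.9-fold lower number from compound 2 to compound 4 (0.46 log units; beyond the scatter), so compound 2 now stands beyond the scatter of both compound 1 and compound 4, though not of compound 3. Nothing on hand gives a reason for these differences. Still open, from the compounds shown here alone, is whether this position needs a ring at all, which an amine, a carboxylic acid or a short alkyl chain would test. Also open, going by these compounds, is whether plain phenyl would fall with pyridin-2-yl or with 4-ethylphenyl.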